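Methyl on the ring nitrogen: compound 1 to compound 3

The source may report more compounds than this note shows. Statements on the series, on what has been measured and on what is new or still open speak of the compounds shown alone.

Compound 1 `CCn1cc(-c2nc3ccccc3[nH]2)c(=O)c2cc(F)c(N3CCNCC3)cc21` stands at the higher end of the two numbers in hand: in a functional assay on KB cells (Homo sapiens) for cytotoxicity, read by MTT assay, with a stated time of 48 h (on this read-out lower numbers stand for stronger inhibition and higher numbers for weaker inhibition), compound 1 gives 10500 nM, while compound 2 `CCn1cc(-c2nc3ccccc3[nH]2)c(=O)c2cc(F)c(N3CCNCC3)nc21` gives 2000 nM in this assay, a gap beyond the scatter. Compound 3 `CCn1cc(-c2nc3ccccc3[nH]2)c(=O)c2cc(F)c(N3CCN(C)CC3)cc21` is not yet measured. It differs from compound 1 by methyl in place of hydrogen on an amine nitrogen in a ring, that is, piperazin-1-yl becomes 4-methylpiperazin-1-yl. Within the data shown here, no measured pair shows this change, so the step of a 1.3-fold lower number from compound 1 to compound 3 (0.12 log units; within the scatter) is expected to be small, likely within the scatter. Compound 3 is estimated at 8000 nM, with a range of 3000 nM to 25000 nM in this assay.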

Compound 3, half-maximal inhibitory concentration: 36700 nM
Compound 3: the middle estimate sits 4.6-fold (0.66 log units) below what was measured, outside the stated range (above it).
By their numbers in this assay, from the lowest: compound 2; then compound 1; then compound 3.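

In this assay, the amine nitrogen in the piperazin-1-yl ring does not tolerate substitution freely: methyl in place of hydrogen there gives a 3.5-fold higher number from compound 1 to compound 3 (0.54 log units; beyond the scatter) and so moves towards weaker inhibition. Among these compounds, this is the first single-change step, and it rests on one pair only. Nothing in hand bears on the reason for this step.

As far as these compounds go, whether a longer chain such as ethyl, or an acetyl group, on this nitrogen would move the number further remains open. Also open, from the compounds shown here alone, is whether methyl gives a similar step on the core of compound 2.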